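The source may hold more compounds than are shown below. What is called first, only, known or untested is meant among the compounds shown, and "the series" means these compounds.

Two compounds of this series have numbers in an assay on isolated protein for displacement of a labelled ligand from metabotropic glutamate receptor 5 (Homo sapiens), with a stated time of 60 min, tested at 1 uM; a higher number here means more inhibition at the concentration tested (going by the name of the read-out), a lower number less inhibition. Compound 1 `COc1ccc(S(=O)(=O)c2cnc3c(F)cccc3c2N2CCC(C)CC2)cc1` gives 67% in this assay, and compound 2 `CC1CCN(c2c(S(=O)(=O)c3ccc(Cl)c(Cl)c3)cnc3c(F)cccc23)CC1` gives 95%. For the measured compounds named here, compound 2 stands highest of the two, with compound 1 its only neighbour at a lower number; the measured step between them, a number 28 percentage points higher from compound 1 to compound 2 (beyond the scatter), is the sole step available so far and concerns the same sulfonyl sulfur that is varied next.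

Compound 3 `CC1CCN(c2c(S(=O)(=O)c3ccc(F)c(F)c3)cnc3c(F)cccc23)CC1` follows compound 2 with a single change: 3,4-difluorophenyl in place of 3,4-dichlorophenyl on a sulfonyl sulfur. Going by the values given here, no measured step swaps one 3,4-dihalophenyl for another, so only the step from compound 1 to compound 2 bears on it, and it shows that the group on the sulfonyl sulfur moves the number modestly. Compound 3 is therefore expected to sit somewhat below compound 2, with a change of about a number 17 percentage points lower from compound 2 to compound 3 (beyond the scatter) in this assay. The estimate for compound 3 is 78%, within a range of 55% to 95%.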

Compound 3, a percentage reported as inhibition, at one concentration (the size of the read-out at that concentration, not a potency): 93%
Compound 3: the middle estimate sits 15 percentage points below what was measured, within the range that was stated.
By their numbers in this assay, from the lowest: compound 1; then compounds 3 and 2 (each within the scatter of the next).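

In this assay, exchanging chlorine for fluorine within the 3,4-dihalophenyl group on the sulfonyl sulfur gives a number 2 percentage points lower from compound 2 to compound 3 (within the scatter), so this change does not separate the two compounds, something the earlier pair could not show. Replacing 4-methoxyphenyl with 3,4-difluorophenyl gives a number 26 percentage points higher from compound 1 to compound 3 (beyond the scatter), so a rise over compound 1 at this position does not require chlorine. Nothing available gives a reason for either step.

Going by these compounds, whether 4-fluorophenyl or unsubstituted phenyl on the sulfonyl sulfur would keep the number with compound 2 and compound 3, or fall towards compound 1, remains open, as does the outcome for a carboxylic acid or an amine on that ring. A read-out at a single concentration also leaves open whether compound 2 and compound 3 differ in potency.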